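Working notes: basic side chain variants, antiproliferative read-out

The compounds below may be only part of what the source reports. "The series", "measured", "known", "first", "only" and "open" are said of these compounds alone.

Measured in a functional assay on DU-145 cells (Homo sapiens) for antiproliferative activity, read by MTT assay, with a stated time of 72 h; on this read-out higher numbers stand for weaker inhibition and lower numbers for stronger inhibition:
compound 1 `CCN(CC)CCCOc1cc2ncnc(Nc3ccc(C#N)cc3)c2cc1OC`: 68900 nM
compound 2 `COc1cc2c(Nc3ccc(C#N)cc3)ncnc2cc1OCCCN1CCC(CO)CC1`: 53200 nM
compound 3 `COc1cc2c(Nc3ccc(C#N)cc3)ncnc2cc1OCCCN1CCC(c2ccccc2)CC1`: 6790 nM

Compound 3 gives the lowest of the three numbers, and both of its steps from the others lie beyond the scatter: a 10-fold lower number from compound 1 to compound 3 (1.01 log units; beyond the scatter) and a 7.8-fold lower number from compound 2 to compound 3 (0.89 log units; beyond the scatter). The remaining pair is closer together, a 1.3-fold lower number from compound 1 to compound 2 (0.11 log units; within the scatter), so compound 1 and compound 2 are not separated on this read-out.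

The next compound, compound 4 `COc1cc2c(Nc3ccc(C#N)cc3)ncnc2cc1OCCCN1CCN(c2ccncc2)CC1`, carries the change (4-(pyridin-4-yl)piperazin-1-yl in place of 4-phenylpiperidin-1-yl on a saturated chain carbon, three bonds along the chain from an oxygen on an aromatic ring). Within the data shown here, the steps that bear on it are the two into compound 3: the large one from compound 1 and the modest one from compound 2, both of which arrived at a phenyl on a saturated ring carbon. Among the measured compounds shown here, compound 4 keeps an aromatic ring at that position of the saturated ring but exchanges it for a pyridinyl and exchanges the piperidine for a piperazine; no measured pair separates these two effects, so the expectation rests only on the retained aromatic ring. The expected step is small and toward a higher number, a 1.8-fold higher number from compound 3 to compound 4 (0.25 log units; within the scatter), close to the scatter. For compound 4 the estimate in this assay is 12000 nM, with a range from 4000 nM to 40000 nM.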

Compound 4, half-maximal inhibitory concentration: 22900 nM
Beside the measured number, compound 4's estimate is 1.9-fold (0.28 log units) below it; the measured number falls inside the stated range.
By their numbers in this assay, from the lowest: compound 3; then compound 4; then compounds 2 and 1 (each within the scatter of the next).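

In this assay, 4-(pyridin-4-yl)piperazin-1-yl on this saturated chain carbon does not match 4-phenylpiperidin-1-yl, with a 3.4-fold higher number from compound 3 to compound 4 (0.53 log units; beyond the scatter), so retaining an aromatic ring on the saturated ring does not by itself preserve the result seen with the phenyl group. The group still improves on both side chains that lack an aromatic ring, with a 2.3-fold lower number from compound 2 to compound 4 (0.37 log units; beyond the scatter) and a 3.0-fold lower number from compound 1 to compound 4 (0.48 log units; beyond the scatter); across these four compounds, the two with an aromatic ring on the saturated ring give the lower numbers, and none goes against this. The change places nitrogen into both rings at once, and no measurement on hand accounts for the loss from compound 3 to compound 4.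

The contributions of the two ring exchanges remain unseparated: 4-phenylpiperazin-1-yl and 4-(pyridin-4-yl)piperidin-1-yl would each isolate one of them. Also open, on these data alone, is whether the order of these side chains holds with a shorter or longer chain between the oxygen and the amine, or with pyridin-3-yl or pyridin-2-yl in place of pyridin-4-yl.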